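Iodo replacement at the chain carbon of compound 2

The source may hold more compounds than are shown below. What is called first, only, known or untested is meant among the compounds shown, and "the series" means these compounds.

In an ADME assay on L6 cells (Rattus norvegicus) for inhibition, read by resazurin assay, with a stated time of 72 h (on this read-out lower numbers stand for stronger inhibition and higher numbers for weaker inhibition), compound 1 `CC(=O)NC[C@H]1O[C@@H](n2cnc3c(N)nc(Cl)nc32)[C@H](OC(C)=O)[C@@H]1OC(C)=O` gives 190000 nM and compound 2 `CC(=O)O[C@@H]1[C@H](OC(C)=O)[C@@H](CN2C(=O)c3ccccc3C2=O)O[C@H]1n1cnc2c(N)nc(Cl)nc21` gives 144000 nM, so the two stand level within the scatter. Compound 3 `CC(=O)O[C@@H]1[C@H](OC(C)=O)[C@@H](CI)O[C@H]1n1cnc2c(N)nc(Cl)nc21` differs from compound 2 by one iodine atom in place of a group of 11 heavy atoms (8 carbon, 1 nitrogen, 2 oxygen; one five-membered non-aromatic ring with 1 hetero atom, one six-membered aromatic ring of carbon only), on a saturated chain carbon bound to a saturated ring carbon. Going by the values given here, the only measured step at this place, a 1.3-fold lower number from compound 1 to compound 2 (0.12 log units; within the scatter), lies within the scatter despite the large change in group size. Among the compounds with values here, no iodo compound has been measured, so this is a thin guide, and no step beyond the scatter is expected in this assay. The expected step is a 1.4-fold lower number from compound 2 to compound 3 (0.16 log units; within the scatter). Compound 3 is estimated at 100000 nM, with an expected range of 30000 nM to 200000 nM.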

Compound 3, half-maximal inhibitory concentration: 86000 nM
The estimate for compound 3 lay 1.2-fold (0.07 log units) above the measured number; measured number inside the range.
By their numbers in this assay, from the lowest: compounds 3, 2 and 1 (each within the scatter of the next, the first and the last beyond it).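

Iodo in place of acetamido on a saturated chain carbon bound to a saturated ring carbon gives a 2.2-fold lower number from compound 1 to compound 3 (0.34 log units; beyond the scatter) in this assay and is the only step at this place beyond the scatter, though a modest one. Iodo in place of the group of 11 heavy atoms gives a 1.7-fold lower number from compound 2 to compound 3 (0.22 log units; within the scatter) and stays within the scatter. Nothing measured here gives a cause for either step. Open, from the compounds shown here alone, is how an amine, an azido group or a chlorine atom on this chain carbon would read in this assay and whether any of them would go beyond iodo.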